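Benzyl on the amine nitrogen: compound 3 to compound 4

The source may hold more compounds than are shown below. What is called first, only, known or untested is meant among the compounds shown, and "the series" means these compounds.

In a functional assay on ECa-109 cells for inhibition, with ECa-109 cell line (Homo sapiens) as the target, read by sulforhodamine B assay (on this read-out higher numbers stand for weaker inhibition and lower numbers for stronger inhibition), compound 1 `Cc1ccc(NC2=CC(=O)c3c(nc4n3[C@H]3OC[C@@H](O)[C@H]3OC4)C2=O)cc1` gives > 4000 nM, which is a limit of the assay and not a number. Compound 2 `COc1ccc(NC2=CC(=O)c3c(nc4n3[C@H]3OC[C@@H](O)[C@H]3OC4)C2=O)cc1` gives 3410 nM. Compound 3 `COc1cccc(NC2=CC(=O)c3c(nc4n3[C@H]3OC[C@@H](O)[C@H]3OC4)C2=O)c1` gives 3340 nM, within the scatter of compound 2 and so level with it. Compound 4 `O=C1C(NCc2ccccc2)=CC(=O)c2c1nc1n2[C@H]2OC[C@@H](O)[C@H]2OC1` carries benzyl in place of 3-methoxyphenyl on an amine nitrogen. Two measured steps change the group on that nitrogen: an at least 1.1-fold lower number from compound 1 to compound 3 (0.07 log units; that floor lies within the scatter), a floor set by a limit (the limit of > 4000 nM in this assay, at which 1 of the 3 values shown sits), and a 1.0-fold lower number from compound 2 to compound 3 (0.01 log units; within the scatter). Neither tests benzyl, so the expectation rests on this flat pair alone. The expected step in this assay is a 1.0-fold higher number from compound 3 to compound 4 (0.02 log units; within the scatter), with none expected beyond the scatter. For compound 4 the estimated value is 3500 nM, with an expected range of 1600 nM to 7000 nM.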

Compound 4, half-maximal inhibitory concentration: > 8000 nM
Compound 4: no number, only a limit (the forecaster's own chance of this, stated with the estimate: 40%); at least 2.2-fold (0.35 log units) between middle value and limit.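

In this assay, for the compounds shown here, benzyl on the amine nitrogen is the first change at this position to give a step beyond the scatter: an at least 2.3-fold higher number from compound 3 to compound 4 (0.37 log units; beyond the scatter), and an at least 2.3-fold higher number from compound 2 to compound 4 (0.37 log units; beyond the scatter). Compound 4 gives > 8000 nM, which is a limit of the assay and not a number, so these steps are floors. The step from compound 1 to compound 4 cannot be read, since both values are limits.

As far as these compounds go, the true size of the loss for compound 4 remains open. So does the outcome for a phenylethyl chain or a methoxy-substituted benzyl on this nitrogen.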